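Hydrogen for methyl on compound 1

A few compounds are considered here, and "the series" means these few. Any claim that something is new, unique, unknown or untested is made for them only; others in the source may bear on it.

Compound 1 (`Cc1ccc(C2CN(S(=O)(=O)c3ccccc3)C(=O)N2)cc1`) is tested in a functional assay on SK-MEL-2 cells (Homo sapiens) for cytotoxicity; a higher number here means a weaker inhibitor, a lower number a stronger inhibitor. In this assay, compound 1 gives > 316000 nM, which is a limit of the assay and not a number. Compound 3 (`Cc1ccc(S(=O)(=O)N2C(=O)NCC2c2ccccc2)cc1`) gives > 316000 nM, which is also a limit. Compound 2 (`O=C1NC(c2ccc(Br)cc2)CN1S(=O)(=O)c1ccc2c(c1)CCC2`) gives 32600 nM, a measured number. The set so far shows (the limit of > 316000 nM in this assay, at which 2 of the 3 values shown sit), and compound 2 goes against that pattern.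

Compound 4 (`O=C1NC(c2ccccc2)CN1S(=O)(=O)c1ccccc1`) is the next case. It follows from compound 1 by one change: hydrogen in place of methyl on an aromatic carbon. In words, hydrogen replaces methyl on an aromatic carbon, so 4-methylphenyl becomes phenyl. Among the measured compounds shown here, no measured pair in the set isolates this change, so any expectation for it is indirect. No step beyond the scatter is expected in this assay, and no direction is favoured. This expectation rests on compound 1, which stands at > 316000 nM, and the assay may again report only a limit for compound 4. The estimated change is a step that the limit leaves unreadable from compound 1 to compound 4. The expected value for compound 4 is 320000 nM. The estimated range for compound 4 runs from 130000 nM to 630000 nM.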

Compound 4, half-maximal inhibitory concentration: 116000 nM
Estimate against measurement, compound 4: 2.8-fold (0.44 log units) above; measured number outside the range, below it.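

In this assay compound 1 gives > 316000 nM, which is a limit of the assay and not a number. Hydrogen in place of methyl on an aromatic carbon, para to a large group, turning 4-methylphenyl into phenyl, gives an at least 2.7-fold lower number from compound 1 to compound 4 (0.43 log units; beyond the scatter); this is the first measured pair at this position, and it shows that the read-out responds to this change, with the phenyl compound giving a measured number rather than a limit. The size of the step remains a lower bound only, because one end of the pair sits at the ceiling of the assay: the limit of > 316000 nM in this assay, at which 2 of the 4 values shown sit.

Only methyl and hydrogen are compared at this position on an otherwise unchanged core, so neither the direction nor the size of the effect of an amine, a carboxylic acid or a longer chain such as ethyl can be read from these compounds. With a single assay among the compounds shown, it also remains open whether the step holds beyond this assay.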